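The source may hold more compounds than are shown below. What is called first, only, known or untested is meant among the compounds shown, and "the series" means these compounds.

Working notes on the alpha-ketooxazole series.

Of the compounds shown here, three have been measured in an assay for inhibition of Fatty-acid amide hydrolase 1 (Rattus norvegicus); a lower number here means a stronger inhibitor, a higher number a weaker inhibitor. Compound 2 `COC(=O)c1cnc(C(=O)CCc2ccc(COc3ccccc3)cc2)o1` gives 1.6 nM. Compound 3 `COC(=O)c1cnc(C(=O)CCc2ccc(Oc3ccccc3)cc2)o1` gives 1.7 nM, and compound 1 `CS(=O)(=O)c1cnc(C(=O)CCc2ccc(-c3ccccc3)cc2)o1` gives 1.2 nM. All three values lie within the scatter of one another, so compound 2 cannot be set apart from either of its neighbours on these numbers.

Within the data shown here, the only single-point step measured so far, a 1.1-fold higher number from compound 2 to compound 3 (0.03 log units; within the scatter), touches the linker between the two aryl groups and leaves the five-membered aromatic ring and its substituent untouched. Among the measured compounds shown here, compound 1 and compound 2 differ in two places at once, so their values say only that a methylsulfonyl-bearing core and a methoxycarbonyl-bearing core both reach the low nanomolar range with different tails.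

Compound 4 `O=C(CCc1ccc(COc2ccccc2)cc1)c1ncc(I)o1` is the next candidate. Relative to compound 2 the change is iodo in place of methoxycarbonyl on an aromatic carbon. For the measured compounds named here, no measured step bears on this position of the core, so the expectation rests on the general observation that every substituent tried so far on that ring carbon carries oxygen acceptors, whereas iodo carries none. A weakening beyond the scatter is therefore expected, with the step of a 7.5-fold higher number from compound 2 to compound 4 (0.88 log units; beyond the scatter) as the working guess, and compound 4 is estimated at 12 nM with a range of 2.5 nM to 60 nM in this assay.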

Compound 4, inhibition constant: 4 nM
Compound 4: the middle estimate sits 3.0-fold (0.48 log units) above what was measured; the measured number falls inside the stated range.
By their numbers in this assay, from the lowest: compounds 1, 2 and 3 (each within the scatter of the next); then compound 4.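

Among these compounds, at this ring carbon, next to the ring oxygen, the step of a 2.5-fold higher number from compound 2 to compound 4 (0.40 log units; beyond the scatter) is the first measured change, and it shows that the position responds to the exchange of methoxycarbonyl for iodo by a modest amount, beyond the scatter. In this assay compound 4 still gives 4 nM with a single heavy atom and no hydrogen-bond acceptors on that carbon, so oxygen acceptors on this carbon are not a requirement for a low nanomolar number within this pair. No measurement among the data shown speaks to what lies behind the size of this step.

A single pair cannot separate what is lost with methoxycarbonyl from what is gained with iodo, and chloro, nitrile, a carboxylic acid or a plain ring hydrogen on the same carbon would help to divide the two. As far as these compounds go, it also stays open whether iodo in place of methoxycarbonyl gives a step of similar size with the phenoxy tail of compound 3, and how iodo compares with methylsulfonyl on an otherwise identical compound.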